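Phenyl in Place of Thiophen-2-yl: an Expected Limit

The compounds below may be only part of what the source reports. "The series", "measured", "known", "first", "only" and "open" are said of these compounds alone.

Among the compounds with values here, compound 1 `Cn1cccc1-c1cc(-c2cccs2)nc(N)c1C#N` is one of three compounds measured in a functional assay on DU-145 cells (Homo sapiens) for inhibition, read by sulforhodamine B assay, with a stated time of 48 h; a lower number here means a stronger inhibitor of growth, a higher number a weaker inhibitor of growth. For compound 1 the result is a limit of the assay, > 100000 nM. Compound 2 `Cn1cccc1-c1cc(-c2cccs2)[nH]c(=O)c1C#N` likewise reaches only a limit in this assay, > 100000 nM. Within the data shown here, compound 3 `COc1ccc(-c2cc(-c3cccn3C)c(C#N)c(N)n2)cc1OC` is the single one with a number, giving 91200 nM in this assay. Where compound 1 stands is therefore told only by the limit of > 100000 nM in this assay, at which 2 of the 3 values shown sit: it is among the compounds that show no measurable growth inhibition up to that boundary. Compound 4 `Cn1cccc1-c1cc(-c2ccccc2)nc(N)c1C#N` differs from compound 1 by a single exchange, (phenyl in place of thiophen-2-yl on an aromatic carbon), that is, phenyl in place of thiophen-2-yl on an aromatic carbon. Among the measured compounds shown here, no measured pair shows the effect of such an exchange, and compound 1 has no number from which a step could be counted. Compound 4 is therefore expected to remain without measurable inhibition, the step being estimated as a number no higher from compound 1 to compound 4 (the limit leaves the size open), nothing beyond the scatter. The estimate for compound 4 in this assay is 100000 nM, within 40000 nM to 300000 nM, most likely reported again only as a limit.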

Compound 4, concentration for 50% growth inhibition: > 100000 nM
Compound 4 gave a limit, no number; the forecaster's own chance of this, stated with the estimate: 70%; the middle value lies on the limit itself.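

Within the data shown here, compound 1 and compound 4 both give only a limit, not a number, so no step between them can be read: the limit of > 100000 nM in this assay, at which 3 of the 4 values shown sit. The compounds shown leave open whether phenyl in place of thiophen-2-yl changes growth inhibition at all in this assay, and by how much.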